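Swapping a Saturated Chain for a Dienyl Chain

The compounds below may be only part of what the source reports. "The series", "measured", "known", "first", "only" and "open" are said of these compounds alone.

Compound 2 `CCCCCCCCCCCCCCCc1cc(=O)c2c(O)c(C)c(OCOC)c(C)c2o1` was tested in a functional assay on MDA-MB-231 cells (Homo sapiens) for antiproliferative activity, read by MTT assay; on this read-out lower numbers stand for stronger inhibition and higher numbers for weaker inhibition. In this assay compound 2 gives only a limit, > 87000 nM, and not a number. Compound 1 `CCCC/C=C\CCCCCCCCCc1cc(=O)c2c(O)cc(OCOC)cc2o1` likewise reaches only a limit of > 87000 nM. Compound 3 `CCCCCCCCCCCCCCCCCCCC1(O)CC(=O)c2c(O)cc(O)cc2O1` also stops at a limit of > 87000 nM. Among the compounds with values here, all three values sit at the limit of > 87000 nM in this assay, at which 3 of the 3 values shown sit, so compound 2 stands level with the others and no measured step exists among them. Compound 4 `CCCCC/C=C\C/C=C\CCCCCCCc1cc(=O)c2c(O)c(C)c(OCOC)c(C)c2o1` differs from compound 2 by deca-1,4-dien-1-yl in place of octyl on a saturated chain carbon, seven bonds along the chain from an aromatic carbon. With every measured compound at the limit, no step size can be drawn from the data, so compound 4 is expected to stay at the limit and the step that the limit leaves unreadable from compound 2 to compound 4 is expected to lie within the scatter. Compound 4 is therefore estimated at 90000 nM, in a range from 40000 nM to 200000 nM.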

Compound 4, half-maximal inhibitory concentration: 16100 nM
Estimate against measurement, compound 4: 5.6-fold (0.75 log units) above; measured number below the stated range.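

In this assay the swap to deca-1,4-dien-1-yl gives an at least 5.4-fold lower number from compound 2 to compound 4 (0.73 log units; beyond the scatter) and yields the only number shown that is not a limit. A change on a saturated chain carbon, seven bonds along the chain from an aromatic carbon, can therefore shift activity in this series. As far as these compounds go, the true size of the step stays unknown because it starts from a limit: the limit of > 87000 nM in this assay, at which 3 of the 4 values shown sit.

The compounds shown leave open whether the two double bonds or the added carbons matter more. A saturated decyl chain in the same place would separate the two.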